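A Single Inverted Stereocentre on a Chain Carbon

The compounds below may be only part of what the source reports. "The series", "measured", "known", "first", "only" and "open" are said of these compounds alone.

In a functional assay on HT-29 cells (Homo sapiens) for antiproliferative activity, read by XTT assay, with a stated time of 72 h (a lower number here means a stronger inhibitor, a higher number a weaker inhibitor), compound 1 (`C=C(C)CCC[C@]1(C)C2=CCC[C@](C)(C[C@@H](O)C3=CC(=O)OC3O)[C@H]2CC[C@H]1C`) gives 2300 nM and compound 2 (`C=C(C)CC[C@]1(C)C2=CCC[C@](C)(C[C@@H](O)C3=CC(=O)OC3O)[C@H]2CC[C@H]1C`) gives 3600 nM while compound 3 (`C=C(C)CC[C@]1(C)C2=CCC[C@](C)(C[C@@H](OC(C)=O)C3=CC(=O)OC3O)[C@H]2CC[C@H]1C`) gives 4800 nM in the same test. Compound 2 holds the middle of these three numbers, within the scatter of each of the others. Compound 4 (`C=C(C)CC[C@]1(C)C2=CCC[C@](C)(C[C@H](O)C3=CC(=O)OC3O)[C@H]2CC[C@H]1C`) differs from compound 2 thus: the two compounds have the same atoms and bonds; at least one stereo element is drawn with a configuration in one of them and without one in the other: 1 of 6 stereo elements differ; a stereocentre at a saturated chain carbon is drawn R in compound 2 and S in compound 4 and a stereocentre at a saturated chain carbon is drawn R in compound 2 and S in compound 4. Among the compounds with values here, no measured step inverts a stereocentre, so the data test this change only indirectly. The nearest guides are a 1.6-fold higher number from compound 1 to compound 2 (0.19 log units; within the scatter) and a 1.3-fold higher number from compound 2 to compound 3 (0.12 log units; within the scatter) and both lie within the scatter. No step beyond the scatter is therefore expected, and the estimate is a 1.1-fold higher number from compound 2 to compound 4 (0.02 log units; within the scatter) in this series. For compound 4 the estimated value is 3800 nM with an expected range from 1600 nM to 9000 nM in this assay as measured here.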

Compound 4, half-maximal inhibitory concentration: 3200 nM
Compound 4: middle estimate off by 1.2-fold (0.07 log units), on the high side; the measured number falls inside the stated range.
By their numbers in this assay, from the lowest: compounds 1, 4, 2 and 3 (each within the scatter of the next, the first and the last beyond it).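

In this assay, within the data shown here, the earlier compounds varied only groups, whereas compound 4 gives a direct reading of a stereocentre at a saturated chain carbon: a 1.1-fold lower number from compound 2 to compound 4 (0.05 log units; within the scatter). In this pair, therefore, the configuration drawn at this position does not separate the two compounds beyond the scatter. The comparison carries one reservation: the fact that one of compounds 2 and 4 is drawn with a defined configuration and the other without, at the place where they differ

The compounds shown leave open whether the same inversion would read alike with an amine in place of the hydroxyl. They also leave open how it would read alongside the acetyl of compound 3.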